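A few compounds are considered here, and "the series" means these few. Any claim that something is new, unique, unknown or untested is made for them only; others in the source may bear on it.

Three compounds have been measured in a functional assay on HCT-116 cells (Homo sapiens) for cytotoxicity, read by MTT assay, with a stated time of 72 h; a lower number here means a stronger inhibitor, a higher number a weaker inhibitor:

Compound 1, `COc1ccc(Nc2nc3ccccc3nc2S(=O)(=O)c2ccccc2)cc1`, gives 2420 nM.
Compound 2, `COc1ccc(Nc2nc3ccccc3nc2S(=O)(=O)c2ccc(C)cc2)cc1`, gives > 50000 nM.
Compound 3, `COc1ccc(Nc2nc3ccccc3nc2S(=O)(=O)c2ccc(Br)cc2)cc1`, gives 3400 nM.

The value of compound 2 is a limit of the assay and not a number. Compound 2 stands at the limit of > 50000 nM in this assay, at which 1 of the 3 values shown sits. Of the two numbers, compound 3 and compound 1 lie within the usual scatter of each other, as the step of a 1.4-fold higher number from compound 1 to compound 3 (0.15 log units; within the scatter) shows. The larger steps, an at least 20-fold higher number from compound 1 to compound 2 (1.31 log units; beyond the scatter) and an at least 14-fold lower number from compound 2 to compound 3 (1.16 log units; beyond the scatter), both concern the ring carrying the sulfonyl group, where methyl, bromo and hydrogen were exchanged.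

Compound 4, `O=S(=O)(c1ccc(Br)cc1)c1nc2ccccc2nc1Nc1ccc(C(F)(F)F)cc1`, keeps the bromo-bearing sulfonyl ring of compound 3 and changes the other end of the molecule: trifluoromethyl in place of methoxy on an aromatic carbon. Among the compounds with values here, none of the measured steps touch this position; they all vary the sulfonyl ring, so they give no direct guide to the size or direction of a change here. The nearest reference is simply compound 3 itself with 3400 nM. Within the data shown here, with no measured step to point elsewhere, compound 4 is expected to give about 4000 nM, with a range of 1200 nM to 14000 nM. This estimate means an expected step of a 1.2-fold higher number from compound 3 to compound 4 (0.07 log units; within the scatter), which would stay within the usual scatter.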

Compound 4, half-maximal inhibitory concentration: 2610 nM
The estimate for compound 4 lay 1.5-fold (0.19 log units) above the measured number, within the range that was stated.
By their numbers in this assay, from the lowest: compounds 1, 4 and 3 (each within the scatter of the next). At a limit, above all of these: compound 2.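

In this assay, moving from 4-methoxyphenyl to 4-(trifluoromethyl)phenyl gives a 1.3-fold lower number from compound 3 to compound 4 (0.11 log units; within the scatter) and so, with the bromo-bearing sulfonyl ring in place, this exchange leaves the cytotoxicity reading within the scatter. Within the data shown here, this is the first look at this end of the molecule, as every earlier step varied the sulfonyl ring, and one of those steps, the exchange of hydrogen for methyl, was large. In this single pair, the hydrogen-bond acceptor counted on methoxy is absent from trifluoromethyl, and the reading still does not move beyond the scatter, although the compounds shown offer no explanation for this outcome.

On these data alone, whether the same exchange would read alike with the unsubstituted sulfonyl ring of compound 1 or the methyl-bearing ring of compound 2 remains open. Also open, as far as these compounds go, is how this position would respond to an amine, a carboxylic acid or a longer chain in place of methoxy or trifluoromethyl.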